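A few compounds are considered here, and "the series" means these few. Any claim that something is new, unique, unknown or untested is made for them only; others in the source may bear on it.

In a functional assay on L1210 cells (Mus musculus) for inhibition (a lower number here means a stronger inhibitor, a higher number a weaker inhibitor), the study set two acyclic compounds side by side. For compound 1 `Nc1nc(=O)ccn1COCCO` the assay reported > 500 ug/mL, a limit rather than a number. Among the measured compounds shown here, compound 2 `Nc1nc(Cl)c2ncn(COCCO)c2n1` gave 69 ug/mL in this assay, the only number in hand, the other value being (the limit of > 500 ug/mL in this assay, at which 1 of the 2 values shown sits). Compound 3 `CC(=O)OCCOCn1cnc2c(Cl)nc(N)nc21` had not yet been tested in this assay. It differs from compound 2 by acetyl in place of hydrogen on an oxygen on a saturated carbon. For the measured compounds named here, no measured pair shows this change, so the size of its effect in this assay is open; the step from compound 2 to compound 3 is expected to stay within the usual scatter or to lean slightly toward a lower number. Compound 3 is therefore expected to give about 50 ug/mL in this assay, with a range from 15 ug/mL to 150 ug/mL. This estimate amounts to an expected step of a 1.4-fold lower number from compound 2 to compound 3 (0.14 log units; within the scatter).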

Compound 3, concentration for 50% inhibition: 91 ug/mL
Estimate against measurement, compound 3: 1.8-fold (0.26 log units) below; measured number inside the range.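

In this assay, acetyl in place of hydrogen on the oxygen of the chain gives a 1.3-fold higher number from compound 2 to compound 3 (0.12 log units; within the scatter), so the two compounds cannot be told apart. Among the compounds shown here, this is the first measured pair at this position, and it shows that the free hydroxy is not needed for inhibition of this size in this assay, since the 2-acetoxyethyl chain serves as well as the 2-hydroxyethyl chain. No measured property shown here bears on the reason for this result.

The compounds shown leave open whether a larger acyl group on this oxygen, such as benzoyl, or a simple methyl ether would also stand level with compound 2. They also leave open what an amine in place of the hydroxy would do.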